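The compounds below may be only part of what the source reports. "The series", "measured", "known", "first", "only" and "open" are said of these compounds alone.

Three compounds share a phenoxyacetamide core and were tested in an assay on HEK293 cells for agonist activity at transient receptor potential cation channel subfamily M member 8 (Homo sapiens), read by fluorescence and calcium flux, with a stated time of 15 min; on this read-out higher numbers stand for an effect only at larger amounts of compound and lower numbers for an effect already at smaller amounts. Compound 1 `CCN(Cc1cccnc1)C(=O)COc1ccc(C)cc1` gives 15400 nM. Compound 2 `CCN(Cc1cccs1)C(=O)COc1cc(C)ccc1O` gives 24 nM. Compound 3 `Cc1ccc(OCC(=O)N(Cc2cccs2)C2COC2)cc1` gives 23000 nM. On these numbers compound 3 stands at the top of the three: its gap to compound 1 lies within the scatter of repeated measurements, so the two cannot be told apart, while its gap to compound 2 lies far beyond it.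

Compound 4 `Cc1ccc(OCC(=O)N(Cc2cccs2)c2cn[nH]c2)cc1` has not yet been measured. It differs from compound 3 in one place: 1H-pyrazol-4-yl in place of oxetan-3-yl on an amide-type nitrogen. Within the data shown here, no pair among the measured compounds isolates this kind of exchange, so there is no measured step to lean on. Among the measured compounds shown here, the new ring brings a hydrogen-bond donor where the oxetane had none, and compound 2, the only compound with a donor, gives 24 nM, but its donor sits elsewhere on the molecule, so that number cannot be carried over. The expected step from compound 3 to compound 4 in this assay is therefore a modest lowering, a 1.9-fold lower number from compound 3 to compound 4 (0.28 log units; within the scatter), not clearly beyond the scatter. Compound 4 is expected to give about 12000 nM, with a range from 3000 nM to 50000 nM.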

Compound 4, half-maximal effective concentration: 1.4 nM
Compound 4: the middle estimate sits 8600-fold (3.93 log units) above what was measured, outside the stated range (below it).
By their numbers in this assay, from the lowest: compound 4; then compound 2; then compounds 1 and 3 (each within the scatter of the next).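

In this assay the exchange of oxetan-3-yl for 1H-pyrazol-4-yl on the amide-type nitrogen gives a 16000-fold lower number from compound 3 to compound 4 (4.22 log units; beyond the scatter) and so shows that this position can have a very large influence on the read-out. With the rest of the molecule unchanged, this single exchange takes compound 3 from the highest number in the set to compound 4 with the lowest. The exchange alters ring size, aromatic character and the hydrogen-bond donor count together, and no measurement at hand explains the step or separates these changes.

From the compounds shown here alone, it remains open whether the ring hydrogen matters, which 1-methyl-1H-pyrazol-4-yl or a plain phenyl ring at this position could help to test. Also open, going by these compounds, is whether the same exchange would have a similar effect on the core of compound 2, which carries a hydroxyl group.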